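The source may hold more compounds than are shown below. What is called first, only, known or untested is meant among the compounds shown, and "the series" means these compounds.

Measured so far:
compound 1, `O=c1c2ccccc2c(Cc2ccc(Cl)cc2)nn1-c1ccc([N+](=O)[O-])cc1`, 29000 nM;
compound 2, `CCn1nc(Cc2ccc(Cl)cc2)c2ccccc2c1=O`, 1300 nM;
compound 3, `COc1ccc(Cc2nn(-c3ccc([N+](=O)[O-])cc3)c(=O)c3ccccc23)cc1OC`, > 100000 nM, a limit.

All three share one core and were tested in a functional assay on aorta with Alpha-1D adrenergic receptor (Rattus norvegicus) as the target; a lower number here means that less compound is needed, a higher number that more compound is needed for the effect. Compound 1 gives 29000 nM. Compound 2 gives 1300 nM; the change is ethyl in place of 4-nitrophenyl on an aromatic nitrogen and the step is a 22-fold lower number from compound 1 to compound 2 (1.35 log units; beyond the scatter). For compound 3 the value > 100000 nM is a limit of the assay, not a number. The difference between compound 1 and compound 3 is 3,4-dimethoxyphenyl in place of 4-chlorophenyl on a saturated chain carbon bound to an aromatic carbon, and the step of an at least 3.4-fold higher number from compound 1 to compound 3 (0.53 log units; beyond the scatter) is open-ended because the limit of > 100000 nM in this assay, at which 1 of the 3 values shown sits, applies to compound 3. Compound 4, `CCn1nc(Cc2ccc(OC)c(OC)c2)c2ccccc2c1=O`, is not yet measured; it differs from compound 3 by ethyl in place of 4-nitrophenyl on an aromatic nitrogen. This is the same kind of change as from compound 1 to compound 2, though the surroundings are described as "meta to a 4-chlorobenzyl group (8 heavy atoms)" in one case and "meta to a large group" in the other. If it acts similarly, the step is expected to be about an at least 6.6-fold lower number from compound 3 to compound 4 (0.82 log units; beyond the scatter), an expectation only, since the starting value of compound 3 is a limit. Compound 4 is therefore estimated at 15000 nM, between 3000 nM and 80000 nM.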

Compound 4, half-maximal effective concentration: 5300 nM
Compound 4: middle estimate off by 2.8-fold (0.45 log units), on the high side; the range from low to high includes it.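

In this assay, ethyl in place of 4-nitrophenyl on the aromatic nitrogen gives an at least 18-fold lower number from compound 3 to compound 4 (1.27 log units; beyond the scatter), so the change carries over to a second core in the same direction and with a large step. Compound 3 gives > 100000 nM, which is a limit. The exact size of this second step therefore stays unknown, and two cores cannot show that the change would behave the same way on others: the same change on two cores in this assay, a 22-fold lower number (1.35 log units; beyond the scatter) from compound 1 to compound 2 and an at least 18-fold lower number (1.27 log units; beyond the scatter) from compound 3 to compound 4; the limit leaves it open whether they differ

The compounds shown leave open how a longer chain, such as butyl, or a chain ending in an amine would compare with ethyl on that nitrogen. They also leave open whether the step would hold with an unsubstituted benzyl group on the core.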